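The source may hold more compounds than are shown below. What is called first, only, known or untested is meant among the compounds shown, and "the series" means these compounds.

Compound 1 `COc1cc(/C=C/C(=O)c2cccc(-n3cc(-c4ccccc4)[nH]c3=O)c2)ccc1O`: 2610 nM
Compound 2 `COc1cc(/C=C/C(=O)c2cccc(-n3cc(-c4ccccc4)[nH]c3=O)c2)cc(OC)c1OC`: 1350 nM
Compound 3 `COc1cc(/C=C/C(=O)c2cccc(-n3cc(-c4cc(OC)c(OC)c(OC)c4)[nH]c3=O)c2)cc(OC)c1OC`: 2120 nM

In a functional assay on M14 cells (Homo sapiens) for inhibition (on this read-out higher numbers stand for weaker inhibition of growth and lower numbers for stronger inhibition of growth), compound 1 stands at the highest of the three numbers, yet its gaps to compound 3 and to compound 2 both fall within the scatter, so the three compounds cannot be separated on these data. Compound 4 `COc1cc(/C=C/C(=O)c2cccc(-n3cc(-c4ccc(Cl)cc4)[nH]c3=O)c2)ccc1O` differs from compound 1 by chloro in place of hydrogen on an aromatic carbon. Among the measured compounds shown here, no measured step carries this exact change. For the measured compounds named here, the one step made on the same phenyl, a 1.6-fold higher number from compound 2 to compound 3 (0.20 log units; within the scatter), stayed within the scatter, and it is the only guide here. Compound 4 is therefore expected to remain close to compound 1, with a 1.0-fold lower number from compound 1 to compound 4 (0.00 log units; within the scatter) expected to be no larger than the scatter. The estimate for compound 4 is 2600 nM, with a range from 1200 nM to 5600 nM.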

Compound 4, concentration for 50% growth inhibition: 2860 nM
Compound 4: the middle estimate sits 1.1-fold (0.04 log units) below what was measured; the measured number falls inside the stated range.
By their numbers in this assay, from the lowest: compounds 2, 3, 1 and 4 (each within the scatter of the next, the first and the last beyond it).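

Working from this assay, the change from phenyl to 4-chlorophenyl gives a 1.1-fold higher number from compound 1 to compound 4 (0.04 log units; within the scatter). Together with the earlier step of a 1.6-fold higher number from compound 2 to compound 3 (0.20 log units; within the scatter), this shows that a single chloro para to a large group, like the three methoxy groups, leaves the number within the scatter, here on the core of compound 1. No supporting data bear on this result. Still open, from the compounds shown here alone, is whether an amine or a carboxylic acid on this phenyl would move the number beyond the scatter. Going by these compounds, whether chloro behaves the same way on the core of compound 2 also remains open.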